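The compounds below may be only part of what the source reports. "The series", "measured", "known", "first", "only" and "open" are said of these compounds alone.

Measured compounds and their values:

Compound 1, `Cc1ccc2nc(C(=O)Nc3c(F)cc(-c4cccc(F)c4)cc3F)c(C)c(O)c2c1`, gives 0.22% in a functional assay on Hep 3B2 cells (Homo sapiens) for antiproliferative activity, read by MTT assay, with a stated time of 24 h, tested at 0.01 ug/mL; on this read-out higher numbers stand for a stronger effect at the one concentration tested and lower numbers for a weaker effect.
Compound 2, `CCOc1ccc2nc(C(=O)Nc3c(F)cc(-c4cccc(F)c4)cc3F)c(C)c(O)c2c1`, gives -0.5% in this assay.
Compound 3, `Cc1c(C(=O)Nc2c(F)cc(-c3cccc(F)c3)cc2F)nc2ccc(C(F)(F)F)cc2c1O`, gives -0.33% in this assay.

Compound 1 has the highest of the three numbers, but its nearest neighbour, compound 3, and its furthest, compound 2, both lie within the scatter of it, so the three compounds cannot be told apart on these readings. The two steps away from compound 1 were a number 0.7 percentage points lower from compound 1 to compound 2 (within the scatter) and a number 0.6 percentage points lower from compound 1 to compound 3 (within the scatter), and the step of a number 0.2 percentage points higher from compound 2 to compound 3 (within the scatter) completes the picture of a flat set, in which changing the group on one aromatic carbon of the shared core leaves the read-out essentially unchanged.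

Compound 4, `Cc1ccc2nc(C(=O)Nc3c(F)cc(-c4cccc(F)c4)cc3F)c(C)c(C(=O)O)c2c1`, is the unmeasured compound. It differs from compound 1 by carboxy in place of hydroxy on an aromatic carbon. Among the measured compounds shown here, none of the measured steps touches this position, so no step bears directly on the change. For the measured compounds named here, what the measured steps do show is that every compound so far sits close to zero, and there is nothing in them to suggest that compound 4 would move away from that level. The step from compound 1 to compound 4 is therefore expected to be a number 0.2 percentage points lower from compound 1 to compound 4 (within the scatter), which is none beyond the scatter. Compound 4 is estimated to give 0% in this assay, within a range from -10% to 10%.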

Compound 4, a percentage reported as inhibition, at one concentration (the size of the read-out at that concentration, not a potency): 0.36%
For compound 4 the middle estimate is 0.4 percentage points below the measured one; the range from low to high includes it.
By their numbers in this assay, from the lowest: compounds 2, 3, 1 and 4 (each within the scatter of the next).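

In this assay, the change of hydroxy to carboxy, on the aromatic carbon opposite the ring nitrogen and ortho to a methyl group, gives a number 's step of a number 0.1 percentage points higher from compound 1 to compound 4 (within the scatter). Among the compounds shown here, the earlier compounds differed only at another aromatic carbon of the shared core, so this is the first reading at this position, and the flat picture now extends to a second place on the core, even though carboxy has 3 heavy atoms where hydroxy has 1. Nothing in the data shown explains why the read-out stays flat.

From the compounds shown here alone, every reading in this assay lies close to zero at the one concentration tested, so it remains open whether either position would matter for a compound with a clear effect, since a change can only be seen to weaken an effect that is there to begin with. Also open, going by these compounds, is what an amine, a methoxy group or a longer chain such as butoxy would give on the carbon opposite the ring nitrogen, and whether the amide linking the two halves of the molecule can be changed.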